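A few compounds are considered here, and "the series" means these few. Any claim that something is new, unique, unknown or untested is made for them only; others in the source may bear on it.

Notes on the series, following the step from compound 3 to compound 4. In a physicochemical assay for lipophilicity, read by HPLC, at pH 7.4 (a higher number here means a more lipophilic compound, a lower number a more polar compound), compound 1 `CC(C)Cc1cc2oc(=O)n(CCC(=O)O)c2cc1Cl` gives 3.03 as its reading. Compound 3 `C[C@@H](Oc1cc2oc(=O)n(CCC(=O)O)c2cc1Cl)c1ccc(Cl)cn1` gives 2.65 as its reading, the lower of the two numbers in hand and beyond the scatter from compound 1. Compound 2 `COc1cc2oc(=O)n(CCC(=O)O)c2cc1Cl` is entered as "not determined" (no result reported) and adds no number to the comparison.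

Compound 4 `C[C@@H](Oc1cc2oc(=O)n(CCC(=O)O)c2cc1Cl)c1ncco1` is the next to be read. The structural change is 1,3-oxazol-2-yl in place of 5-chloropyridin-2-yl on a saturated chain carbon bound to an oxygen on an aromatic ring and a saturated chain carbon on a saturated chain carbon bound to an oxygen on an aromatic ring and a saturated chain carbon. Among the compounds with values here, no measured pair differs in one place only, so no measured step can serve as a guide, and the expectation rests on this exchange alone, starting from compound 3 at 2.65 in this assay terms. An estimated step of a number 0.85 log units lower from compound 3 to compound 4 (beyond the scatter) is expected, downward and beyond the scatter. For compound 4 the estimate is 1.8 with 1.3 to 2.3 as the expected range.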

Compound 4, distribution coefficient: 1.11
For compound 4 the middle estimate is 0.69 log units above the measured one, and the stated range ends above it.
By their numbers in this assay, from the lowest: compound 4; then compound 3; then compound 1.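

In this assay, the exchange of 5-chloropyridin-2-yl for 1,3-oxazol-2-yl on a saturated chain carbon bound to an oxygen on an aromatic ring and a saturated chain carbon gives a number 1.54 log units lower from compound 3 to compound 4 (beyond the scatter), the first one-place step measured at this position, and it shows that the reading depends strongly on the group held there. On the aromatic carbon, the group of 8 heavy atoms carrying the 1,3-oxazol-2-yl ring in place of the group of 4 heavy atoms gives a number 1.92 log units lower from compound 1 to compound 4 (beyond the scatter), so the larger group does not raise the reading here. Nothing at hand explains the size of either step.

Within the data shown here, with only this exchange, the loss of chlorine cannot be separated from the change of ring; an unsubstituted pyridin-2-yl or a chlorinated 1,3-oxazol-2-yl would divide the step. Steps involving compound 2 cannot be read, and the effect of an amine at this position remains open.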